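Fluoro in Place of Methoxy: A Small Change Weighed

A few compounds are considered here, and "the series" means these few. Any claim that something is new, unique, unknown or untested is made for them only; others in the source may bear on it.

Of the compounds shown here, two have been measured in a functional assay on A549 cells (Homo sapiens) for inhibition, read by CCK-8 assay, with a stated time of 72 h, tested at 2 uM; a higher number here means more inhibition of growth at the concentration tested, a lower number less inhibition of growth. Compound 1, `Cc1cc(C)cc(SCc2ccc(/C=C/C(=O)Nc3ccccc3N)cc2)c1`, gives 46.1% in this assay. Compound 2, `COc1ccc(SCc2ccc(C(=O)Nc3ccccc3N)cc2)cc1`, gives 45.7%. On these numbers compound 2 stands lowest of the two, yet its nearest neighbour, compound 1, lies only slightly higher, a gap that falls within the scatter of repeated measurements, so the two cannot be told apart. Going by the values given here, no pair of measured compounds differing in a single place is available, so there is no measured step to calibrate against.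

Compound 3, `Nc1ccccc1NC(=O)c1ccc(CSc2ccc(F)cc2)cc1`, has not yet been measured. It differs from compound 2 in one place: fluoro in place of methoxy on an aromatic carbon. Both groups are small and sit on the same aromatic carbon, para to a large group. Among the compounds with values here, with no measured step of comparable kind to lean on, the step of a number 2.7 percentage points lower from compound 2 to compound 3 (within the scatter) is expected to be small, in no clear direction, and not beyond the scatter. Compound 3 is therefore estimated at 43% in this assay, within a range from 25% to 60%.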

Compound 3, percent growth inhibition at one concentration: 43.4%
Compound 3: the middle estimate sits 0.4 percentage points below what was measured, within the range that was stated.
By their numbers in this assay, from the lowest: compounds 3, 2 and 1 (each within the scatter of the next).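

In this assay, going by these compounds alone, fluoro in place of methoxy on an aromatic carbon, para to a large group, gives a number 2.3 percentage points lower from compound 2 to compound 3 (within the scatter), and this is the first measured step between two compounds that differ in one place. It shows that compound 2 and compound 3 cannot be told apart in this read-out, even though a group of 2 heavy atoms with 1 hydrogen-bond acceptor gives way to a group of 1 heavy atom with 0 hydrogen-bond acceptors, so 4-methoxyphenyl and 4-fluorophenyl read alike here. Nothing at hand bears on why this pair reads alike.

The compounds shown leave open whether an amine, a carboxylic acid or a longer chain such as butoxy on the same aromatic carbon would give a step beyond the scatter, or whether this position tolerates such groups as evenly as it does these two. They also leave open whether compound 2 and compound 3 would still read alike at another concentration, as this single step speaks only for the one concentration tested.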